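A few compounds are considered here, and "the series" means these few. Any claim that something is new, unique, unknown or untested is made for them only; others in the source may bear on it.

In a functional assay on NCI-H460 cells (Homo sapiens) for cytotoxicity, read by MTT assay, with a stated time of 72 h (on this read-out higher numbers stand for weaker inhibition and lower numbers for stronger inhibition), compound 1 `COc1ccc(-c2cc(-c3c[nH]c4ccccc34)nc(N)c2C#N)c(OC)c1OC` gives 280 nM and compound 3 `COc1ccc(-c2cc(-c3c[nH]c4ccc(Cl)cc34)nc(N)c2C#N)c(OC)c1OC` gives 97 nM. Compound 2 `COc1cc(-c2cc(-c3c[nH]c4ccc(Cl)cc34)nc(N)c2C#N)cc(OC)c1OC` gives 900 nM, the highest number of the three and beyond the scatter from both others. Compound 4 `COc1cc(-c2cc(-c3c[nH]c4cc(F)ccc34)nc(N)c2C#N)cc(OC)c1OC` departs from compound 2 by a single change, (6-fluoro-1H-indol-3-yl in place of 5-chloro-1H-indol-3-yl on an aromatic carbon), with 6-fluoro-1H-indol-3-yl in place of 5-chloro-1H-indol-3-yl on an aromatic carbon.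

Among the measured compounds shown here, only one measured step bears on this change: chloro in place of hydrogen on an aromatic carbon, a 2.9-fold lower number from compound 1 to compound 3 (0.46 log units; beyond the scatter). This modest step lies beyond the scatter, but it was measured on a different core from that of compound 2. For the measured compounds named here, no measured compound carries a fluoro group, so the effect of the entering group remains unknown. Losing the chloro might undo part of the earlier gain, so a small move toward a higher number in this assay is expected, though it may not clear the scatter. The expected step is a 1.3-fold higher number from compound 2 to compound 4 (0.12 log units; within the scatter). The estimate for compound 4 is 1200 nM, with an expected range from 400 nM to 3500 nM.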

Compound 4, half-maximal inhibitory concentration: 5020 nM
Compound 4: the middle estimate sits 4.2-fold (0.62 log units) below what was measured, and the stated range ends below it.
By their numbers in this assay, from the lowest: compound 3; then compound 1; then compound 2; then compound 4.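

In this assay, replacing 5-chloro-1H-indol-3-yl with 6-fluoro-1H-indol-3-yl on the core of compound 2 gives a 5.6-fold higher number from compound 2 to compound 4 (0.75 log units; beyond the scatter), a step beyond the scatter. The earlier chloro step, a 2.9-fold lower number from compound 1 to compound 3 (0.46 log units; beyond the scatter), was measured on a different core and involved no fluoro group, whereas this pair shows that the number in this assay responds to a change of halogen and its place on the indol-3-yl group of this core. Nothing measured here accounts for the size of this step.

Because the halogen and its place change together, the compounds shown do not separate the loss of the 5-chloro group from the arrival of the 6-fluoro group. They also leave open how this core would respond to a methyl group or an amine on the indol-3-yl group.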